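The compounds below may be only part of what the source reports. "The series", "measured", "known", "first", "only" and "open" are said of these compounds alone.

Measured so far, in a functional assay on LCLC-103H cells (Homo sapiens) for cytotoxicity, with a stated time of 96 h; on this read-out higher numbers stand for weaker inhibition of growth and lower numbers for stronger inhibition of growth:

Compound 1, `O=C(Oc1cccc2cccnc12)c1cc2c(cc1Cl)SC(N(c1ccc(F)cc1)S(=O)(=O)c1ccc(Br)s1)=NS2(=O)=O`, gives 5300 nM.
Compound 2, `COC(=O)c1cc2c(cc1Cl)SC(N(N(C)C)S(=O)(=O)c1ccc(Br)s1)=NS2(=O)=O`, gives 19100 nM.
Compound 3, `O=C(Oc1cccc2cccnc12)c1cc2c(cc1Cl)SC(N(c1ccc(F)cc1)S(=O)(=O)c1ccc(Cl)cc1)=NS2(=O)=O`, gives 4600 nM.

Compound 1 and compound 3 differ in one place only: 4-chlorophenyl in place of 5-bromothiophen-2-yl on a sulfonyl sulfur. That change gave a 1.2-fold lower number from compound 1 to compound 3 (0.06 log units; within the scatter), a step that is within the scatter. Compound 2 stands highest of the three numbers, and its difference from the core of compound 1 is not broken down here. Compound 4, `COC(=O)c1cc2c(cc1Cl)SC(N(N(C)C)S(=O)(=O)c1ccc(Cl)cc1)=NS2(=O)=O`, which is not yet measured, differs from compound 2 by the same change: 4-chlorophenyl in place of 5-bromothiophen-2-yl on a sulfonyl sulfur. The place of the change is the same in both pairs. Because the earlier step of a 1.2-fold lower number from compound 1 to compound 3 (0.06 log units; within the scatter) was small, the step from compound 2 to compound 4 is expected to be small as well, about a 1.2-fold lower number from compound 2 to compound 4 (0.08 log units; within the scatter). Compound 4 is therefore estimated at 16000 nM, with a likely range from 8000 nM to 32000 nM.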

Compound 4, concentration for 50% growth inhibition: 19600 nM
The estimate for compound 4 lay 1.2-fold (0.09 log units) below the measured number; measured number inside the range.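

In this assay, putting 4-chlorophenyl in place of 5-bromothiophen-2-yl on the sulfonyl sulfur gave a 1.0-fold higher number from compound 2 to compound 4 (0.01 log units; within the scatter), so the swap again made no measurable difference. The two cores respond alike, and the two steps do not differ: the same change on two cores in this assay, a 1.2-fold lower number (0.06 log units; within the scatter) from compound 1 to compound 3 and a 1.0-fold higher number (0.01 log units; within the scatter) from compound 2 to compound 4, 1.2-fold (0.07 log units) apart, within the scatter of two such steps

This shows that the swap carried over as a neutral one between these two cores, but both steps are close to nothing, so it does not show that a change with a real effect would carry over as well.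

Still open, as far as these compounds go, is what a sulfonyl group bearing a plain alkyl chain, or an aromatic ring bearing an amine, would do. From the compounds shown here alone, compound 1 and compound 2 differ in more than one place, so the share of each difference remains unknown.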